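Benzylation of a ring hydroxy in a flavone series

The source may hold more compounds than are shown below. What is called first, only, known or untested is meant among the compounds shown, and "the series" means these compounds.

Measured so far in a functional assay on KB 3-1 cells (Homo sapiens) for inhibition, with a stated time of 72 h; a lower number here means a stronger inhibitor, a higher number a weaker inhibitor:
compound 1 `CC(=O)Oc1cc2oc(-c3ccccc3)cc(=O)c2c(O)c1OC(C)=O`, 69300 nM
compound 2 `CC(=O)Oc1cc2oc(-c3ccccc3)cc(=O)c2c(OCc2ccccc2)c1OC(C)=O`, 12200 nM
compound 3 `O=c1cc(-c2ccccc2)oc2cc(O)c(OCc3ccccc3)c(O)c12`, 3200 nM

Compound 1 and compound 2 share a core and differ in one place, (benzyl in place of hydrogen on an oxygen on an aromatic ring); that change gives a 5.7-fold lower number from compound 1 to compound 2 (0.75 log units; beyond the scatter). Compound 3 carries the lowest number of the three in this assay, and it differs from compound 1 by more than one change, so the difference between the two cores is not broken down here.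

Compound 4 `O=c1cc(-c2ccccc2)oc2cc(O)c(OCc3ccccc3)c(OCc3ccccc3)c12` is not yet measured. It differs from compound 3 by benzyl in place of hydrogen on an oxygen on an aromatic ring, the same change that separates compound 1 from compound 2, at a place whose surroundings read the same in both pairs. Within the data shown here, on that basis compound 4 is expected to give a lower number than compound 3, with a step of about a 3.6-fold lower number from compound 3 to compound 4 (0.55 log units; beyond the scatter) expected, close in size to the one seen from compound 1 to compound 2, because the step of a 5.7-fold lower number from compound 1 to compound 2 (0.75 log units; beyond the scatter) is the only direct reading of this change. The uncertainty is wider than that single step, since the two cores are not alike. Compound 4 is estimated at 900 nM, within roughly 300 nM to 3000 nM.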

Compound 4, half-maximal inhibitory concentration: > 100000 nM
Compound 4 was reported as a limit; the forecaster's own chance of this, stated with the estimate: 0%; middle value at least 110-fold (2.04 log units) from the limit.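

In this assay compound 4 gives > 100000 nM, which is a limit of the assay and not a number. Benzyl in place of hydrogen on an oxygen on an aromatic ring does not carry over from one core to the other in this series, as the new step, an at least 31-fold higher number from compound 3 to compound 4 (1.49 log units; beyond the scatter), runs opposite in direction to the earlier one: the same change on two cores in this assay, a 5.7-fold lower number (0.75 log units; beyond the scatter) from compound 1 to compound 2 and an at least 31-fold higher number (1.49 log units; beyond the scatter) from compound 3 to compound 4, at least 170-fold (2.24 log units) apart, beyond the scatter of two such steps. Among these compounds, with only two pairs, this shows that the outcome of the change depends on the core, but it does not show which difference between the cores decides the direction, so a reading from one core gives no safe estimate for the other.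

The compounds shown leave open whether the reversal goes with the acetyl groups carried by compound 1 and compound 2 or with the free hydroxy groups of compound 3. They also leave open whether methyl, a longer alkyl chain or a chain ending in an amine or a carboxylic acid in place of benzyl on that oxygen would follow either step.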